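A few compounds are considered here, and "the series" means these few. Any claim that something is new, unique, unknown or untested is made for them only; others in the source may bear on it.

Measured so far:
compound 1 `CN(C)c1ccc(C(=O)N[C@@H](CCCCCC(=O)NO)C(=O)NCc2ccccc2)cc1`: 12000 nM
compound 2 `CN(C)c1ccc(C(=O)N[C@H](CCCCCC(=O)NO)C(=O)NCc2ccccc2)cc1`: 1000 nM
compound 3 `CN(C)c1ccc(C(=O)NC(CCCCCC(=O)NO)C(=O)NCc2ccccc2)cc1`: 870 nM

In a functional assay on NFF cells (Homo sapiens) for antiproliferative activity (a higher number here means a weaker inhibitor, a lower number a stronger inhibitor), compound 1 gives the highest of the three numbers; the nearest is compound 2 with a 12-fold lower number from compound 1 to compound 2 (1.08 log units; beyond the scatter), and compound 3 lies further at a 14-fold lower number from compound 1 to compound 3 (1.14 log units; beyond the scatter). Those two steps rest on the fact that compounds 1 and 2 differ only in the configuration as drawn and (the fact that one of compounds 1 and 3 is drawn with a defined configuration and the other without, at the place where they differ), so they concern only the drawn configuration.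

Compound 4 `O=C(CCCCC[C@H](NC(=O)c1cc2ccccc2[nH]1)C(=O)NCc1ccccc1)NO` keeps the configuration of compound 1 and changes the group on the carbonyl: 1H-indol-2-yl in place of 4-(dimethylamino)phenyl on a carbonyl carbon. For the measured compounds named here, none of the measured steps touches this part of the molecule, so they give no direction for it, and no change beyond the scatter is expected in this assay. Compound 4 is therefore estimated at 9000 nM, in the range 2500 nM to 30000 nM, which means a 1.3-fold lower number from compound 1 to compound 4 (0.12 log units; within the scatter).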

Compound 4, half-maximal inhibitory concentration: 1260 nM
Compound 4: middle estimate off by 7.1-fold (0.85 log units), on the high side, and the stated range ends above it.
By their numbers in this assay, from the lowest: compounds 3, 2 and 4 (each within the scatter of the next); then compound 1.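

In this assay, for the compounds shown here, the step for this swap is a 9.5-fold lower number from compound 1 to compound 4 (0.98 log units; beyond the scatter), so the group on the carbonyl can itself move the number, which the earlier steps could not show as they concerned only the drawn configuration. The two groups have the same heavy-atom count, but the incoming one brings a five-membered aromatic ring and a hydrogen-bond donor. Nothing available explains why this swap moves the number.

The compounds shown leave open whether the 1H-indol-2-yl group would act the same way in the opposite drawn configuration. They also leave open how a plain phenyl or a pyridine ring would behave on this carbonyl.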